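The source may hold more compounds than are shown below. What is called first, only, known or untested is meant among the compounds shown, and "the series" means these compounds.

Measured so far:
- compound 1 `CCn1c(C(=O)NCC#N)ccc1C(CC)(CC)c1ccc(OCCC(O)(CC)CC)c(C)c1`: 17800 nM in a functional assay on PC-3 cells (Homo sapiens) for antiproliferative activity, read by MTT assay, with a stated time of 48 h; a higher number here means a weaker inhibitor, a lower number a stronger inhibitor
- compound 2 `CCn1c(C(=O)NCCN)ccc1C(CC)(CC)c1ccc(OCCC(O)(CC)CC)c(C)c1`: 2420 nM in this assay
- compound 3 `CCC(C)C(NC(=O)c1ccc(C(CC)(CC)c2ccc(OCCC(O)(CC)CC)c(C)c2)n1CC)C(=O)O`: 13800 nM in this assay

Compound 1 stands at the highest number of the three. Its nearest neighbour is compound 3, with a 1.3-fold lower number from compound 1 to compound 3 (0.11 log units; within the scatter), a gap within the scatter. Among the compounds with values here, the only clear step seen is a 7.4-fold lower number from compound 1 to compound 2 (0.87 log units; beyond the scatter), and the reverse side of that appears as a 5.7-fold higher number from compound 2 to compound 3 (0.76 log units; beyond the scatter).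

Compound 4 `CCn1c(C(=O)NC(C)C(=O)O)ccc1C(CC)(CC)c1ccc(OCCC(O)(CC)CC)c(C)c1` differs from compound 1 by 1-carboxyethyl in place of cyanomethyl on an amide-type nitrogen. Within the data shown here, the step that bears most directly on this is the one from compound 1 to compound 3, where a 1-carboxy-2-methylbutyl also replaced the cyanomethyl and the number moved only within the scatter. Compound 2 shows that an aminomethyl in that place lowered the number, but compound 4 carries a carboxy group, as compound 3 does, not an amine. For compound 4 in this assay the expected step is therefore a 1.2-fold lower number from compound 1 to compound 4 (0.07 log units; within the scatter), not beyond the scatter. Compound 4 is estimated at 15000 nM, within 6000 nM to 40000 nM.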

Compound 4, half-maximal inhibitory concentration: 11700 nM
The estimate for compound 4 lay 1.3-fold (0.11 log units) above the measured number; the range from low to high includes it.
By their numbers in this assay, from the lowest: compound 2; then compounds 4, 3 and 1 (each within the scatter of the next).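

In this assay, a second carboxy compound behaves as compound 3 did: 1-carboxyethyl in place of cyanomethyl on the amide-type nitrogen stays within the scatter (a 1.5-fold lower number from compound 1 to compound 4 (0.18 log units; within the scatter)). Methyl in place of sec-butyl on the saturated chain carbon also stays within the scatter (a 1.2-fold lower number from compound 3 to compound 4 (0.07 log units; within the scatter)), so these two carboxy side chains are not told apart here, and compound 2 with its 2-aminoethyl group remains separate from both, as 1-carboxyethyl in place of 2-aminoethyl shows (a 4.8-fold higher number from compound 2 to compound 4 (0.68 log units; beyond the scatter)). No measurement at hand gives a reason for these steps.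

The compounds shown leave open whether the lower number of compound 2 depends on the primary amine itself or on its spacing. A 3-aminopropyl group, a 2-(dimethylamino)ethyl group or a 2-hydroxyethyl group on that nitrogen would separate these possibilities.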